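Amide aryl replacements on a shared chloro-substituted core

The compounds below may be only part of what the source reports. "The series", "measured", "known", "first", "only" and "open" are said of these compounds alone.

Compound 1 `O=C(Nc1ccc(Cl)c(-c2nnc3c(Cl)cccn23)c1)c1ccccn1` gives 75500 nM in a functional assay on HeLa cells (Homo sapiens) for antiproliferative activity, read by MTT assay, with a stated time of 72 h; a lower number here means a stronger inhibitor, a higher number a weaker inhibitor. Compound 2 `CS(=O)(=O)c1ccc(C(=O)Nc2ccc(Cl)c(-c3nnc4c(Cl)cccn34)c2)cc1` gives > 100000 nM in this assay, a limit of the assay rather than a number. Compound 3 `Cc1cc(Cl)ccc1C(=O)Nc1ccc(Cl)c(-c2nnc3c(Cl)cccn23)c1` gives > 100000 nM in this assay, again a limit and not a number.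

Compound 3 therefore stands at the ceiling of what this assay reports, the same ceiling at which compound 2 sits (the limit of > 100000 nM in this assay, at which 2 of the 3 values shown sit). The step of an at least 1.3-fold higher number from compound 1 to compound 3 (0.12 log units; that floor lies within the scatter) and the step of an at least 1.3-fold higher number from compound 1 to compound 2 (0.12 log units; that floor lies within the scatter) both have floors within the scatter, and the step that the two limits leave unreadable from compound 2 to compound 3 cannot be read.

Compound 4 `O=C(Nc1ccc(Cl)c(-c2nnc3c(Cl)cccn23)c1)c1cccnc1Cl` carries 2-chloropyridin-3-yl in place of 4-chloro-2-methylphenyl on a carbonyl carbon. Both measured steps that bear on this position, from compound 1 outward, are bounded only at their lower end and leave the direction of any further change open. The step of a number no higher from compound 3 to compound 4 (the limit leaves the size open) is expected to stay within the scatter, with the value likely remaining a limit. Compound 4 is estimated at 100000 nM in this assay, with a range from 30000 nM to 300000 nM.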

Compound 4, half-maximal inhibitory concentration: 87500 nM
Compound 4: the middle estimate sits 1.1-fold (0.06 log units) above what was measured; measured number inside the range.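

In this assay compound 4 gives 87500 nM, a readable number, as compound 1 does.

Compound 2 and compound 3 stop at a limit of the assay: the limit of > 100000 nM in this assay, at which 2 of the 4 values shown sit.

Against those two limits, only floors can be read (an at least 1.1-fold lower number from compound 3 to compound 4 (0.05 log units; that floor lies within the scatter) and an at least 1.1-fold lower number from compound 2 to compound 4 (0.05 log units; that floor lies within the scatter)), so no real gain over 4-chloro-2-methylphenyl or 4-(methylsulfonyl)phenyl is shown. Among these compounds, the one step between two actual numbers (a 1.2-fold higher number from compound 1 to compound 4 (0.06 log units; within the scatter)) means that 2-chloropyridin-3-yl and pyridin-2-yl cannot be told apart at this position.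

Going by these compounds, whether an aliphatic amine or a carboxylic acid on the aryl group of this amide would move the number beyond the scatter remains open. Also open, on these data alone, is whether the shared core, rather than the group on the carbonyl carbon, sets this level of activity.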